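The compounds below may be only part of what the source reports. "The series", "measured", "known", "first", "only" and "open" are said of these compounds alone.

Working notes on the series, following the step from compound 1 `Cc1cc(C)c(-c2nc(CN3CCC(C(=O)NCCCN4C[C@H](C)C[C@H](C)C4)CC3)c(C)o2)c(C)c1` to compound 4 `Cc1oc(-c2c(Cl)cccc2Br)nc1CN1CCC(C(=O)NCCCN2C[C@H](C)C[C@H](C)C2)CC1` in an ADME assay on microsomes from liver (Rattus norvegicus) for metabolic stability, read by LC-MS, using NADPH, at 37 degrees C; on this read-out higher numbers stand for a longer-lived compound and lower numbers for a shorter-lived compound.

In this assay compound 1 gives > 0.5 h, which is a limit of the assay and not a number. For the measured compounds named here, it is the only such case so far: the limit of > 0.5 h in this assay, at which 1 of the 3 values shown sits. Compound 2 `CC[C@@H]1C[C@H](CC)CN(CCCNC(=O)C2CCN(Cc3nc(-c4c(F)cccc4F)oc3C)CC2)C1` gives 0.065 h, and compound 3 `Cc1ccccc1-c1nc(CN2CCC(C(=O)NCCCN3CC4CCCC(C4)C3)CC2)c(C)o1` gives 0.123 h. These two values lie within the usual scatter of each other. Going by the values given here, both compounds differ from compound 1 in more than one place, so no measured step isolates a single change.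

Compound 4 keeps the rest of compound 1 and carries 2-bromo-6-chlorophenyl in place of 2,4,6-trimethylphenyl on an aromatic carbon. Among the compounds with values here, the only guide to direction is weak: compound 2 at 0.065 h and compound 3 at 0.123 h also lack the 2,4,6-trimethylphenyl. A moderate move toward a shorter-lived compound is therefore expected in this assay, and the estimated step is an at least 1.7-fold lower number from compound 1 to compound 4 (0.25 log units; that floor lies within the scatter). A result at the same limit remains possible.

For compound 4 the expected half-life is 0.28 h, with an estimated range of 0.12 h to 0.6 h.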

Compound 4, half-life: 0.0233 h
Estimate against measurement, compound 4: 12-fold (1.08 log units) above; measured number below the stated range.
By their numbers in this assay, from the lowest: compound 4; then compounds 2 and 3 (each within the scatter of the next). At a limit, above all of these: compound 1.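

In this assay, for the compounds shown here, replacing 2,4,6-trimethylphenyl with 2-bromo-6-chlorophenyl on an aromatic carbon of the five-membered aromatic ring gives an at least 21-fold lower number from compound 1 to compound 4 (1.33 log units; beyond the scatter) and provides the first reading of a single change. With the rest of compound 1 held constant, the half-life therefore depends strongly on which of these two aryl groups sits at this position, something compound 2 and compound 3 could not show, since their steps to the other compounds cannot be read. Compound 1 stands at a limit and not at a number, so the size of the step is only a floor: the limit of > 0.5 h in this assay, at which 1 of the 4 values shown sits.

The methyl groups leave and the chlorine and bromine enter in a single step, so the compounds shown do not tell which part of the exchange goes with the shorter half-life, and no cause can be assigned to it. Also open, from the compounds shown here alone, is how the half-life would respond at this position to 2,6-dichlorophenyl, to 2,6-dimethylphenyl or to a pyridine ring on an otherwise unchanged compound 1.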